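From nitro to amino on compound 3

A few compounds are considered here, and "the series" means these few. Any claim that something is new, unique, unknown or untested is made for them only; others in the source may bear on it.

Values in a functional assay on HeLa cells (Homo sapiens) for inhibition, read by MTT assay, with a stated time of 72 h; on this read-out lower numbers stand for stronger inhibition and higher numbers for weaker inhibition
- compound 1 (`COc1cc(OC)c(OC)cc1/C=C/C(=O)c1c(OC)cc(O)c(CC=C(C)C)c1O`) (> 50000 nM, a limit of the assay)
- compound 2 (`COc1cc(OC)c(C(=O)/C=C/c2ccc(O)c(O)c2)c(OC)c1`) (15800 nM)
- compound 3 (`COc1cc(OC)c(C(=O)/C=C/c2ccc([N+](=O)[O-])cc2)c(OC)c1`) (8000 nM)

Compound 1 gives only a limit. Within the data shown here, compound 3 (8000 nM) and compound 2 (15800 nM) give the only two true numbers, and they lie within the scatter of each other. Compound 4 (`COc1cc(OC)c(C(=O)/C=C/c2ccc(N)cc2)c(OC)c1`) carries amino in place of nitro on an aromatic carbon, para to a large group (amino in place of nitro on an aromatic carbon). Among the measured compounds shown here, no measured step covers this change. In this assay the expected step is small, with no firm direction and nothing beyond the scatter (a 1.1-fold lower number from compound 3 to compound 4 (0.06 log units; within the scatter)). The estimated value for compound 4 is 7000 nM (expected range 2000 nM to 25000 nM).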

Compound 4, half-maximal inhibitory concentration: > 50000 nM
Compound 4 ended at the assay's limit; the forecaster's own chance of this, stated with the estimate: 5%; middle value at least 7.1-fold (0.85 log units) away from the limit.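

In this assay, among these compounds, the aromatic carbon para to a large group proves sensitive to this change, which the earlier compounds could not show: amino in place of nitro gives an at least 6.2-fold higher number from compound 3 to compound 4 (0.79 log units; beyond the scatter). The 4-aminophenyl group also compares poorly with 3,4-dihydroxyphenyl, with an at least 3.1-fold higher number from compound 2 to compound 4 (0.50 log units; beyond the scatter). The value of compound 4 is a limit of the assay, not a number: the limit of > 50000 nM in this assay, at which 2 of the 4 values shown sit.

Open, from the compounds shown here alone, is whether the weaker result follows from the free amino group itself or from the loss of nitro. An acetamide or a dimethylamino group at this place would separate the two.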